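The source may hold more compounds than are shown below. What is called first, only, known or untested is meant among the compounds shown, and "the series" means these compounds.

Measured compounds: compound 1 `C=CCn1c(=O)/c(=C\c2ccccc2Cl)[nH]c(=O)/c1=C\c1ccccc1OC` gives 6400 nM in a functional assay on Huh-7 cells (Homo sapiens) for cytotoxicity, read by CCK-8 assay, with a stated time of 72 h; on this read-out higher numbers stand for weaker inhibition and lower numbers for stronger inhibition; compound 2 `C=CCn1c(=O)/c(=C\c2ccc(Cl)c(Cl)c2)[nH]c(=O)/c1=C\c1ccccc1OC` gives "not active" (no number reported); compound 3 `C=CCn1c(=O)/c(=C\c2cc(Br)ccc2F)[nH]c(=O)/c1=C\c1ccccc1OC` gives "not active" (no number reported).

Compound 3 thus stands without a number in this assay, and compound 2 shares this position, so only compound 1 carries a measured value. Compound 4 `C=CCn1c(=O)/c(=C\c2cccc(Br)c2)[nH]c(=O)/c1=C\c1ccccc1OC` differs from compound 3 by hydrogen in place of fluoro on an aromatic carbon, a single-atom change on the halogenated ring. Among the compounds with values here, no step between measured compounds is available, so the size of this step cannot be read from the data; the removal of one fluorine is expected to shift the read-out little, if at all, beyond the usual scatter. Compound 4 is therefore estimated at 20000 nM, in a range from 5000 nM to 80000 nM, with a fair chance of again returning no number.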

Compound 4, half-maximal inhibitory concentration: 2300 nM
Compound 4: the middle estimate sits 8.7-fold (0.94 log units) above what was measured, outside the stated range (below it).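

In this assay, hydrogen in place of fluoro turns the "not active" result of compound 3 into a measured value for compound 4, so this single-atom change on the ring can decide whether a number is obtained at all, though the size of that step cannot be read. With 3-bromophenyl in place of 2-chlorophenyl there is a 2.8-fold lower number from compound 1 to compound 4 (0.44 log units; beyond the scatter) on the shared core. Nothing available explains either difference.

Going by these compounds, whether an amine or a nitrile at the place of the bromo would keep this value remains open. So does the effect of a carboxylic acid or a longer chain on this ring.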